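This account rests on a few compounds, and the source may have more. Where it says the series, first, only, none or still open, it means among the compounds named here.

Measured so far in a functional assay on Molt4/C8 cells (Homo sapiens) for cytotoxicity; a lower number here means a stronger inhibitor, a higher number a weaker inhibitor:
- Compound 1 `COc1ccc(NC(=O)/C=C/C(=O)N2C/C(=C\c3ccc([N+](=O)[O-])cc3)C(=O)/C(=C/c3ccc([N+](=O)[O-])cc3)C2)cc1`: 940 nM
- Compound 2 `O=C(/C=C/C(=O)N1C/C(=C\c2ccc([N+](=O)[O-])cc2)C(=O)/C(=C/c2ccc([N+](=O)[O-])cc2)C1)Nc1ccccc1`: 360 nM

Of these two numbers, compound 2 gives the lower one in this assay. For the measured compounds named here, its nearest neighbour is compound 1, and the step between them, a 2.6-fold lower number from compound 1 to compound 2 (0.42 log units; beyond the scatter), is the only measured step in this set. It shows that taking the methoxy off that aromatic carbon lowered the number by a modest amount, beyond the scatter.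

Compound 3 `Cc1ccc(NC(=O)/C=C/C(=O)N2C/C(=C\c3ccc([N+](=O)[O-])cc3)C(=O)/C(=C/c3ccc([N+](=O)[O-])cc3)C2)cc1` differs from compound 2 by methyl in place of hydrogen on an aromatic carbon. Going by the values given here, no measured step puts a methyl at this place, so the only guide is the methoxy step, which ran in the other direction when a group at this position was removed. A small substituent returning to the same aromatic carbon might therefore be expected to move the number upward slightly, though a methyl is not a methoxy and the step might also stay within the scatter. For compound 3 the expected step from its parent is a 1.5-fold higher number from compound 2 to compound 3 (0.18 log units; within the scatter). Compound 3 is accordingly estimated at 550 nM, with a likely range from 250 nM to 1200 nM.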

Compound 3, half-maximal inhibitory concentration: 700 nM
For compound 3 the middle estimate is 1.3-fold (0.10 log units) below the measured one; the range from low to high includes it.
By their numbers in this assay, from the lowest: compounds 2, 3 and 1 (each within the scatter of the next, the first and the last beyond it).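

In this assay, putting a methyl on the aromatic carbon that carried the methoxy gives a 1.9-fold higher number from compound 2 to compound 3 (0.29 log units; within the scatter), and the comparison of the two substituents gives a 1.3-fold lower number from compound 1 to compound 3 (0.13 log units; within the scatter). For the compounds shown here, both steps lie within the scatter, so the 4-methylphenyl compound cannot be separated from either the phenyl or the 4-methoxyphenyl compound, and only the step between hydrogen and methoxy remains beyond the scatter; at this position, the three compounds therefore form a small graded set without a clear break at the methyl. Nothing measured here gives a reason for these numbers, so the result describes the position without explaining it.

The compounds shown leave open whether a chlorine atom, an amine or a carboxylic acid on this same aromatic carbon, or a longer chain such as propyl, would give a number clearly apart from those of the hydrogen and methoxy compounds. They also leave open whether a methyl or methoxy on another carbon of this ring would give steps like these.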